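Chloro to fluoro on the aryl ring of compound 3

The source may hold more compounds than are shown below. What is called first, only, known or untested is meant among the compounds shown, and "the series" means these compounds.

Three members of the series have numbers in an in vitro functional assay on HEK285-7 cells for antagonist activity at prostaglandin D2 receptor 2 (Homo sapiens), read by BRET and beta-arrestin recruitment; a lower number here means a stronger inhibitor, a higher number a weaker inhibitor. Compound 1 `O=C(O)Cc1sc(Nc2ccc(Cl)cc2)nc1-c1ccc(F)cc1` gives 1900 nM in this assay, compound 2 `O=C(O)Cc1sc(-c2ccccc2)nc1-c1ccc(F)cc1` gives 860 nM, and compound 3 `O=C(O)Cc1sc(Cc2ccccc2)nc1-c1ccc(Cl)cc1` gives 4100 nM. Compound 3 stands highest of the three: compound 1 is nearest to it, compound 2 furthest, and both gaps are beyond the scatter.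

Among the compounds with values here, the only single-point step measured so far, a 2.2-fold lower number from compound 1 to compound 2 (0.34 log units; beyond the scatter), concerns the group on the other side of the shared core and does not touch the fluoro-bearing ring, so it gives no direct guide to the present change.

Compound 4 `O=C(O)Cc1sc(Cc2ccccc2)nc1-c1ccc(F)cc1` differs from compound 3 by fluoro in place of chloro on an aromatic carbon. Within the data shown here, no measured pair shows this exchange on its own; compounds 1 and 2 carry the fluoro ring, compound 3 the chloro ring, but their other groups differ as well, so their values cannot be read as a halogen step.

With nothing in the measured data bearing on the exchange, a step of a 1.2-fold lower number from compound 3 to compound 4 (0.07 log units; within the scatter) is expected, that is, one that is not expected to go beyond the scatter in either direction. Compound 4 is therefore estimated at 3500 nM in this assay, with a range from 1500 nM to 8000 nM.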

Compound 4, half-maximal inhibitory concentration: 180 nM
Compound 4: the middle estimate sits 19-fold (1.29 log units) above what was measured; the whole stated range lies above it.
By their numbers in this assay, from the lowest: compound 4; then compound 2; then compound 1; then compound 3.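

In this assay, within the data shown here, this is the first direct reading of the halogen at this position: a 23-fold lower number from compound 3 to compound 4 (1.36 log units; beyond the scatter), a large step for a change of one heavy atom that adds or removes no ring, hydrogen-bond donor, hydrogen-bond acceptor or net charge. With the 4-fluorophenyl ring held constant, the group on the other side of the shared core can also be read, giving a 4.8-fold lower number from compound 2 to compound 4 (0.68 log units; beyond the scatter) for benzyl in place of phenyl and an 11-fold lower number from compound 1 to compound 4 (1.02 log units; beyond the scatter) for benzyl in place of (4-chlorophenyl)amino, so the ranking of that group now depends on seeing it alongside the right halogen: benzyl appears in both compound 3, the weakest of the four, and compound 4, the strongest. No measurement at hand explains the size of the halogen step.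

Going by these compounds, whether an exchange of chloro for fluoro gives a step of similar size with phenyl or (4-chlorophenyl)amino on the core remains open. Also open, on these data alone, is how a hydrogen, methoxy or trifluoromethyl at the same place on the ring would compare with fluoro and chloro when benzyl is kept.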